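This account rests on a few compounds, and the source may have more. Where it says the series, first, only, none or still open, it means among the compounds named here.

Measured compounds and values:
- compound 1 `CC(C)c1cc(OCC(=O)[C@H](CC(=O)O)NC(=O)[C@@H](NC(=O)COc2cccc3ccccc23)C(C)C)no1`: > 200000 nM
- compound 2 `CC(C)[C@H](NC(=O)COc1cccc2ccccc12)C(=O)N[C@@H](CC(=O)O)C(=O)CSc1nc(-c2ccccc2)c(-c2ccccc2)[nH]1`: > 200000 nM
- compound 3 `CC(C)[C@H](NC(=O)COc1cccc2ccccc12)C(=O)N[C@@H](CC(=O)O)C(=O)CSc1nc(-c2ccccc2)cs1`: > 200000 nM

Every value shown here is a limit of the assay, not a number. In a functional assay on Jurkat cells (Homo sapiens) for inhibition (on this read-out lower numbers stand for stronger inhibition and higher numbers for weaker inhibition), compound 3 gives > 200000 nM, which is such a limit. Compound 1 and compound 2 show the same limit, so the three values cannot be told apart, and compound 3 stands nowhere in particular among them.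

The change to compound 4 `CC(C)[C@H](NC(=O)COc1cccc2ccccc12)C(=O)N[C@@H](CC(=O)O)C(=O)CSc1nc2ccccc2o1` is 1,3-benzoxazol-2-yl in place of 4-phenyl-1,3-thiazol-2-yl on a sulfur. Among the compounds with values here, the only measured step that touches the same part of the molecule is a step that the two limits leave unreadable from compound 1 to compound 3, and it is unreadable because of the limit of > 200000 nM in this assay, at which 3 of the 3 values shown sit. Within the data shown here, no measured step therefore tells how large the move from compound 3 to compound 4 might be, nor in which direction.

With nothing to suggest a measurable number, compound 4 is expected to sit at the same limit in this assay, estimated at 200000 nM, with a range from 50000 nM to 600000 nM. This estimate means an expected step of a number no higher from compound 3 to compound 4 (the limit leaves the size open), within the scatter.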

Compound 4, half-maximal inhibitory concentration: > 200000 nM
Compound 4 was reported as a limit; the forecaster's own chance of this, stated with the estimate: 85%; the middle value lies on the limit itself.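

In this assay compound 4 gives > 200000 nM which is a limit and not a number. The steps to compound 4 from compound 1 and compound 3 cannot be read, because the values share one limit: the limit of > 200000 nM in this assay, at which 4 of the 4 values shown sit. Compound 1, compound 2, compound 3 and compound 4 leave open which change, if any, would give a measurable value in this assay here.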